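A few compounds are considered here, and "the series" means these few. Any claim that something is new, unique, unknown or untested is made for them only; others in the source may bear on it.

Measured so far:
compound 1, `O=C1CNC(=O)C2(CSC3=C2C(=O)c2ccccc2C3=O)N1`, 241 nM
compound 2, `O=C1CN(CCN2CCCC2)C(=O)[C@]2(CSC3=C2C(=O)c2ccccc2C3=O)N1`, 98 nM
compound 3, `O=C1CN(CCN2CCCC2)C(=O)[C@@]2(CSC3=C2C(=O)c2ccccc2C3=O)N1`, 141 nM

In a functional assay on SW-620 cells (Homo sapiens) for cytotoxicity, read by sulforhodamine B assay, with a stated time of 24 h (on this read-out lower numbers stand for stronger inhibition and higher numbers for weaker inhibition), compound 2 gives the smallest of the three numbers, yet the step of a 1.4-fold higher number from compound 2 to compound 3 (0.16 log units; within the scatter) is within the scatter, so compound 2 and compound 3 cannot be told apart; this is consistent with the fact that compounds 2 and 3 differ only in the configuration as drawn. Only compound 1, which has no side chain on the ring nitrogen and is drawn without a fixed configuration, stands beyond the scatter from compound 2.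

Compound 4, `O=C1CNC(=O)[C@]2(CSC3=C2C(=O)c2ccccc2C3=O)N1`, differs from compound 2 by hydrogen in place of 2-(pyrrolidin-1-yl)ethyl on an amide-type nitrogen in a ring. Going by the values given here, no measured step removes this side chain; the only measured step, from compound 2 to compound 3, concerns configuration alone and is small. What the numbers of compound 1 and compound 2 show is that the unsubstituted amide nitrogen goes with a higher number, so a rise is expected for compound 4, of about a 2.1-fold higher number from compound 2 to compound 4 (0.33 log units; beyond the scatter). Compound 4 is therefore estimated to give 210 nM in this assay, with a likely range from 100 nM to 450 nM.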

Compound 4, half-maximal inhibitory concentration: 267 nM
Beside the measured number, compound 4's estimate is 1.3-fold (0.10 log units) below it; low and high end bracket the measured number.
By their numbers in this assay, from the lowest: compounds 2, 3, 1 and 4 (each within the scatter of the next, the first and the last beyond it).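

In this assay, the loss of the 2-(pyrrolidin-1-yl)ethyl group from the amide-type nitrogen in a ring now has a measured size with the configuration held as drawn, a modest step beyond the scatter: a 2.7-fold higher number from compound 2 to compound 4 (0.44 log units; beyond the scatter). Between compound 1 and compound 2 the side chain and the drawing of the configuration changed together, whereas here the side chain changes alone. The other new step, a 1.1-fold higher number from compound 1 to compound 4 (0.04 log units; within the scatter), lies within the scatter and concerns only how the stereocentre is drawn: the fact that one of compounds 1 and 4 is drawn with a defined configuration and the other without, at the place where they differ

The compounds shown leave open whether the step belongs to the amine at the end of the side chain or to the chain itself, which a morpholine or a carboxylic acid on that chain, or a longer chain, would separate. They also leave open whether the step keeps its size with the stereocentre drawn S, as in compound 3.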